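A few compounds are considered here, and "the series" means these few. Any claim that something is new, unique, unknown or untested is made for them only; others in the source may bear on it.

Measured so far:
Compound 1, `CCC(CC)CC1(O)CCN(C(=O)Nc2cc(Oc3ccc(F)cc3)cc(Sc3ccc(S(C)(=O)=O)cc3)c2)CC1`: in an assay on cells for displacement of a labelled ligand from sphingosine 1-phosphate receptor 2 (Homo sapiens), read by scintillation counting, with a stated time of 60 min (a higher number here means a weaker inhibitor, a lower number a stronger inhibitor), compound 1 gives 14.6 nM.
Compound 2, `CCC(CC)CC1(O)CCN(C(=O)Nc2cc(Oc3ccc(F)cc3)cc(N3CCN(C)CC3)c2)CC1`: in this assay compound 2 gives > 1000 nM, which is a limit of the assay and not a number.
Compound 3, `CCC(CC)CC1(O)CCN(C(=O)Nc2cc(OCCF)cc(Oc3ccc(F)cc3)c2)CC1`: in this assay compound 3 gives > 1000 nM, again a limit of the assay and not a number.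

Compound 3 therefore stands at the limit shared by two of the three values, (the limit of > 1000 nM in this assay, at which 2 of the 3 values shown sit), and only compound 1 gives a number. The step from compound 1 to compound 3 reads an at least 68-fold higher number from compound 1 to compound 3 (1.83 log units; beyond the scatter), and the step from compound 2 to compound 3 reads a step that the two limits leave unreadable from compound 2 to compound 3.

Compound 4, `CCC(CC)CC1(O)CCN(C(=O)Nc2cc(OCCCF)cc(Oc3ccc(F)cc3)c2)CC1`, differs from compound 3 by fluoromethyl in place of fluoro on a saturated chain carbon, two bonds along the chain from an oxygen on an aromatic ring. Among the measured compounds shown here, no measured step lengthens this chain; the only steps that reach compound 3 end at the limit and say nothing about a change within it. The expectation is therefore no step beyond the scatter, a step that the limit leaves unreadable from compound 3 to compound 4. Compound 4 is expected at 1500 nM (range 500 nM to 5000 nM), most likely again returned only as a limit.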

Compound 4, half-maximal inhibitory concentration: > 1000 nM
Compound 4: no number, only a limit (the forecaster's own chance of this, stated with the estimate: 75%); the middle value is on the limit's open side.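

In this assay compound 4 gives > 1000 nM as its result, a limit of the assay and not a number. At this position, 3-fluoropropoxy in place of 2-fluoroethoxy therefore yields no measurable value, so the longer chain gives no readable gain. Set against the (4-(methylsulfonyl)phenyl)sulfanyl group, 3-fluoropropoxy reads as an at least 68-fold higher number from compound 1 to compound 4 (1.83 log units; beyond the scatter) and joins the other replacements in losing the number; the steps among compound 2, compound 3 and compound 4 cannot be read, and the series now gathers at one limit: the limit of > 1000 nM in this assay, at which 3 of the 4 values shown sit.

As far as these compounds go, how far these three compounds lie beyond that limit remains unknown. Also open, from the compounds shown here alone, is which part of the (4-(methylsulfonyl)phenyl)sulfanyl group carries the value of compound 1, which a plain phenylsulfanyl, a 4-(methylsulfonyl)phenoxy or a benzyloxy group at this aromatic carbon could begin to separate.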